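From pyridinylmethyl to benzyl on the chain amine

The source may hold more compounds than are shown below. What is called first, only, known or untested is meant among the compounds shown, and "the series" means these compounds.

Of the compounds shown here, three sharing one core have been measured in a functional assay on cells for agonist activity at C-X-C chemokine receptor type 4 (Homo sapiens), read by fluorescence and calcium flux, with a stated time of 90 s; on this read-out lower numbers stand for an effect already at smaller amounts and higher numbers for an effect only at larger amounts of compound. Compound 1 `c1cncc(CN(CCCCN(C[C@H]2Cc3ccccc3CN2)[C@H]2CCCc3cccnc32)Cc2cccnc2)c1` carries two (pyridin-3-yl)methyl groups on the chain amine nitrogen. In this assay compound 1 gives > 30000 nM, which is a limit of the assay and not a number. Compound 2 `c1ccc(CN(CCCCN(C[C@H]2Cc3ccccc3CN2)[C@H]2CCCc3cccnc32)Cc2ccccc2)cc1` carries two benzyl groups on that nitrogen. In this assay compound 2 gives > 30000 nM, also a limit. Compound 3 `c1cncc(CNCCCCN(C[C@H]2Cc3ccccc3CN2)[C@H]2CCCc3cccnc32)c1` bears a single (pyridin-3-yl)methyl group there. In this assay compound 3 gives > 30000 nM, again a limit. Compound 3 thus stands together with the other two: all three sit at the limit of > 30000 nM in this assay, at which 3 of the 3 values shown sit, and the step that the two limits leave unreadable from compound 1 to compound 3 cannot be read, both its ends being limits.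

Compound 4 `c1ccc(CNCCCCN(C[C@H]2Cc3ccccc3CN2)[C@H]2CCCc3cccnc32)cc1` is reached from compound 3 by phenyl in place of pyridin-3-yl on a saturated chain carbon bound to an amine nitrogen. Going by the values given here, no measured step mirrors this change directly; compound 1 and compound 2 show the same swap done twice over, yet both values are limits, so no size can be taken from them. The expectation for this assay is therefore that compound 4 remains at the limit, with no step beyond scatter that the data could support, a step that the limit leaves unreadable from compound 3 to compound 4. Compound 4 is estimated at 40000 nM, within 10000 nM to 200000 nM.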

Compound 4, half-maximal effective concentration: > 30000 nM
Compound 4: only a limit was reported; the forecaster's own chance of this, stated with the estimate: 85%; the middle value does not contradict the limit.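

Compound 4 gives > 30000 nM in this assay, again a limit of the assay and not a number, so the steps to compound 4 from compound 2 and from compound 3 cannot be read. The compounds shown leave open whether phenyl in place of pyridin-3-yl, or hydrogen in place of benzyl, changes the half-maximal effective concentration at all.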